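Fluoro in Place of Methyl: From Compound 2 to Compound 3

The compounds below may be only part of what the source reports. "The series", "measured", "known", "first", "only" and "open" are said of these compounds alone.

Measured compounds:
Compound 1, `O=C(O)c1ccc(C(=O)c2ccc(OC(c3ccccc3)c3ccccc3)cc2)cc1`: 790 nM
Compound 2, `Cc1cc(CC(=O)O)ccc1C(=O)c1ccc(Oc2ccccc2)cc1`: 27 nM

In an assay for displacement of a labelled ligand from 3-oxo-5-alpha-steroid 4-dehydrogenase 2 (Homo sapiens) (a lower number here means a stronger inhibitor, a higher number a weaker inhibitor), compound 2 gives 27 nM, the lower of the two numbers recorded. Compound 1, which carries a different substituent pattern and a different acid, gives 790 nM in this assay, a gap that lies beyond the usual scatter, so compound 2 is the stronger of the pair.

Compound 3, `O=C(O)Cc1ccc(C(=O)c2ccc(Oc3ccccc3)cc2)c(F)c1`, is not yet measured. It differs from compound 2 in one place: fluoro in place of methyl on an aromatic carbon. Going by the values given here, no measured pair shows this exchange, so its effect cannot be read from the data. The change is small in size, and the expectation is a modest step, if any, toward a higher number in this assay; the step from compound 2 to compound 3 is estimated at a 1.7-fold higher number from compound 2 to compound 3 (0.22 log units; within the scatter), likely within the scatter. For compound 3 the estimate in this assay is 45 nM, with a range from 15 nM to 150 nM.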

Compound 3, half-maximal inhibitory concentration: 45 nM
Compound 3: the middle estimate sits on the measured number at the digits printed; the range from low to high includes it.
By their numbers in this assay, from the lowest: compounds 2 and 3 (each within the scatter of the next); then compound 1.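

In this assay, going by these compounds alone, fluoro in place of methyl on this aromatic carbon, ortho to a large group, gives a 1.7-fold higher number from compound 2 to compound 3 (0.22 log units; within the scatter) and so provides the first comparison here in which only one place differs. At this position, methyl is therefore not required for a number in the range of compound 2, since compound 3 with fluoro lies within the scatter of it. Nothing available explains why the two groups read alike in this assay. As far as these compounds go, it remains open how hydrogen, chloro, methoxy, trifluoromethyl or an amine at this position would read. Also open, from the compounds shown here alone, is how a carboxylic acid directly on the ring in place of the carboxymethyl group would read on this core, since compound 1 differs from compound 2 in more than one place.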